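Dropping one methoxy from compound 1

The compounds below may be only part of what the source reports. "The series", "measured", "known", "first", "only" and "open" are said of these compounds alone.

Compound 1 `COc1cc(-c2cc(/C=C/C(=O)c3ccc(N)cc3)[nH]n2)cc(OC)c1OC` and compound 2 `COc1cc(-c2cc(/C=C/C(=O)c3ccc(Cl)c(Cl)c3)[nH]n2)cc(OC)c1OC` share the core and differ only at the aryl ketone. In a functional assay on NCI-H23 cells (Homo sapiens) for cytotoxicity, read by sulforhodamine B assay, with a stated time of 48 h, tested at 1 uM (on this read-out higher numbers stand for a weaker effect at the one concentration tested and lower numbers for a stronger effect), compound 1 gives 95% and compound 2 gives 95%; the step of no change at the digits printed from compound 1 to compound 2 (within the scatter) is flat. Compound 3 `COc1ccc(-c2cc(/C=C/C(=O)c3ccc(N)cc3)[nH]n2)cc1OC` differs from compound 1 by hydrogen in place of methoxy on an aromatic carbon. For the measured compounds named here, no measured step touches this ring, so the single step on record, no change at the digits printed from compound 1 to compound 2 (within the scatter), bears on it only indirectly, and no shift beyond the scatter is expected in this assay. Compound 3 is estimated at 94%, range 82% to 102%. The expected step is therefore a number 1 percentage points lower from compound 1 to compound 3 (within the scatter).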

Compound 3, a percentage reported as activity, at one concentration (the size of the read-out at that concentration, not a potency): 99%
Compound 3: the middle estimate sits 5 percentage points below what was measured, and the stated range covers the measured number.
By their numbers in this assay, from the lowest: compounds 1, 2 and 3 (each within the scatter of the next).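

Hydrogen in place of methoxy is the first measured change on this ring, and a number 4 percentage points higher from compound 1 to compound 3 (within the scatter) in this assay leaves the step inside the scatter. At the one concentration tested, this methoxy therefore makes no readable difference to the effect of the 4-aminophenyl ketone. No measurement on hand bears on why this result is flat.

Still open, on these data alone, is whether a hydroxy group or an amine on this aromatic carbon would move the read-out. Also open, as far as these compounds go, is whether removing the methoxy matters with the 3,4-dichlorophenyl ketone of compound 2.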